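Chain extension in the ester series: compound 3 to compound 4

The source may hold more compounds than are shown below. What is called first, only, known or untested is meant among the compounds shown, and "the series" means these compounds.

Measured so far:
- compound 1, `CCCCCCOC(=O)CCC(=O)N1CCN(CCCOc2cc3c(Nc4ccc(F)c(Cl)c4)ncnc3cc2OC)CC1`: 42.9%
- compound 2, `CCCCCCCCOC(=O)CCC(=O)N1CCN(CCCOc2cc3c(Nc4ccc(F)c(Cl)c4)ncnc3cc2OC)CC1`: 21.7%
- compound 3, `CCCCCCCCCCCCCCCCOC(=O)CCC(=O)N1CCN(CCCOc2cc3c(Nc4ccc(F)c(Cl)c4)ncnc3cc2OC)CC1`: 74.3%

In a functional assay on A549 cells (Homo sapiens) for cytotoxicity, read by MTT assay, with a stated time of 24 h, tested at 80 uM (a lower number here means a stronger effect, a higher number a weaker effect of the compound at the concentration tested), compound 3 stands highest of the three, its number being a number 31.4 percentage points higher from compound 1 to compound 3 (beyond the scatter) and a number 52.6 percentage points higher from compound 2 to compound 3 (beyond the scatter). The next member is compound 4, `CCCCCCCCCCCCCCCCCCOC(=O)CCC(=O)N1CCN(CCCOc2cc3c(Nc4ccc(F)c(Cl)c4)ncnc3cc2OC)CC1`, which differs from compound 3 by ethyl in place of hydrogen on a saturated chain carbon, ten or more bonds along the chain from an oxygen next to a carbonyl group. Going by the values given here, the steps that bear on this are the same kind of addition at shorter chains: a number 21.2 percentage points lower from compound 1 to compound 2 (beyond the scatter), against the larger chain extensions that gave a number 31.4 percentage points higher from compound 1 to compound 3 (beyond the scatter) and a number 52.6 percentage points higher from compound 2 to compound 3 (beyond the scatter). No consistent direction emerges, since compound 2 goes against the rise seen for compound 3. A small addition to an already long chain is therefore expected to change this assay little, as a number 3.7 percentage points higher from compound 3 to compound 4 (within the scatter). Compound 4 is estimated at 78%, within 60% to 95%.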

Compound 4, a percentage reported as activity, at one concentration (the size of the read-out at that concentration, not a potency): 86.7%
For compound 4 the middle estimate is 8.7 percentage points below the measured one; measured number inside the range.
By their numbers in this assay, from the lowest: compound 2; then compound 1; then compound 3; then compound 4.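

In this assay ethyl added this far along the chain still moves the number, with a number 12.4 percentage points higher from compound 3 to compound 4 (beyond the scatter) as the step. Compound 4 stands highest of the four, with a number 65 percentage points higher from compound 2 to compound 4 (beyond the scatter) and a number 43.8 percentage points higher from compound 1 to compound 4 (beyond the scatter) as its steps from the two shorter esters. The same ethyl addition thus runs in opposite directions at the two chain lengths: the same change on two cores in this assay, a number 21.2 percentage points lower (beyond the scatter) from compound 1 to compound 2 and a number 12.4 percentage points higher (beyond the scatter) from compound 3 to compound 4, 33.6 percentage points apart, beyond the scatter of two such steps.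

On these data alone, whether a longer chain raises the number further remains open. So does the behaviour of chains intermediate between those of compound 2 and compound 3, or of a carboxylic acid at the chain end.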